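This account rests on a few compounds, and the source may have more. Where it says the series, first, only, none or still open, it means among the compounds named here.

Compound 3 `CCOC(=O)C1CCN(CCCOc2cc3ncnc(Nc4ccc(C#N)cc4)c3cc2OC)CC1` gives 89900 nM in a functional assay on A549 cells (Homo sapiens) for antiproliferative activity, read by MTT assay, with a stated time of 72 h (a lower number here means a stronger inhibitor, a higher number a weaker inhibitor), the highest of the two numbers shown. Compound 2 `COc1cc2c(Nc3ccc(C#N)cc3)ncnc2cc1OCCCN1CCC(O)CC1` gives 29900 nM, and a 3.0-fold higher number from compound 2 to compound 3 (0.48 log units; beyond the scatter). Compound 1 `COc1cc2c(Nc3ccc(C#N)cc3)ncnc2cc1OCCCN(C)Cc1ccccc1` reaches only the limit > 100000 nM in this assay. Compound 4 `COc1cc2c(Nc3ccc(C#N)cc3)ncnc2cc1OCCCN1CCC(c2ccccc2)CC1` differs from compound 3 by phenyl in place of ethoxycarbonyl on a saturated ring carbon. Among the measured compounds shown here, no measured step exchanges these two groups directly; the nearest guides are an at least 1.1-fold lower number from compound 1 to compound 3 (0.04 log units; that floor lies within the scatter) and a 3.0-fold higher number from compound 2 to compound 3 (0.48 log units; beyond the scatter), and both compound 1 and compound 3 are weak. Compound 1 with its benzyl(methyl)amino group sits at the limit of > 100000 nM in this assay, at which 1 of the 3 values shown sits. Compound 4 is therefore expected to show a 1.0-fold higher number from compound 3 to compound 4 (0.00 log units; within the scatter), with an estimated value of 90000 nM and a range from 30000 nM to 250000 nM.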

Compound 4, half-maximal inhibitory concentration: 9500 nM
Compound 4: the middle estimate sits 9.5-fold (0.98 log units) above what was measured, and the stated range ends above it.
By their numbers in this assay, from the lowest: compound 4; then compound 2; then compound 3. At a limit, above all of these: compound 1.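

At the saturated ring carbon three ring bonds from the ring nitrogen, phenyl, with 0 hydrogen-bond donors and 0 hydrogen-bond acceptors, gives a 9.5-fold lower number from compound 3 to compound 4 (0.98 log units; beyond the scatter) and a 3.1-fold lower number from compound 2 to compound 4 (0.50 log units; beyond the scatter), which makes compound 4 the strongest of the four in this assay. Exchanging benzyl(methyl)amino for 4-phenylpiperidin-1-yl gives an at least 10-fold lower number from compound 1 to compound 4 (1.02 log units; beyond the scatter). That step rests on a limit for compound 1: the limit of > 100000 nM in this assay, at which 1 of the 4 values shown sits. The compounds shown leave open whether a cyclohexyl group on this ring carbon, which has no aromatic ring, would match phenyl, and whether a benzyl group would.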